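Amine side chain: from compound 2 to compound 3

The source may hold more compounds than are shown below. What is called first, only, known or untested is meant among the compounds shown, and "the series" means these compounds.

Read-out in a functional assay (aorta) with Rattus norvegicus as the target (on this read-out lower numbers stand for stronger inhibition and higher numbers for weaker inhibition), as follows:
compound 1 `CCCCN(CCCC)CCCCCOc1ccc(S(=O)(=O)c2c(CC)cn3ccccc23)cc1` gives 97.4 nM
compound 2 `CCCCN(CCCC)CCCCOc1ccc(S(=O)(=O)c2c(CC)cn3ccccc23)cc1` gives 33.3 nM
compound 3 `CCc1cn2ccccc2c1S(=O)(=O)c1ccc(OCCCN2CCCCC2)cc1` is not yet measured

Compound 2 at 33.3 nM holds the lower of the two numbers. Compound 3 carries piperidin-1-yl in place of (dibutylamino)methyl on a saturated chain carbon, three bonds along the chain from an oxygen on an aromatic ring. For the measured compounds named here, only one measured step bears on this, the modest 2.9-fold lower number from compound 1 to compound 2 (0.47 log units; beyond the scatter) and it kept the dibutylamino group. Going by the values given here, no measured step covers the ring. In this assay a modest move to a higher number is therefore expected, with its direction uncertain. The estimated step is a 2.4-fold higher number from compound 2 to compound 3 (0.38 log units; beyond the scatter) in size. For compound 3 the estimate is 80 nM (range 20 nM to 320 nM).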

Compound 3, half-maximal inhibitory concentration: 357 nM
Estimate against measurement, compound 3: 4.5-fold (0.65 log units) below, and the stated range ends below it.
By their numbers in this assay, from the lowest: compound 2; then compound 1; then compound 3.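

In this assay, the change to piperidin-1-yl brings an 11-fold higher number from compound 2 to compound 3 (1.03 log units; beyond the scatter), a large step, and a 3.7-fold higher number from compound 1 to compound 3 (0.56 log units; beyond the scatter), a modest one, so compound 3 sits highest of the three and the lower number seen from compound 1 to compound 2 does not extend to it. For the compounds shown here, this position therefore responds more strongly to this change of amine and chain together than to the single step between the dibutylamino compounds. No available evidence accounts for the rise. The compounds shown leave open how much of it belongs to the ring and how much to the chain, and whether a diethylamino or morpholin-4-yl group in this place would read closer to compound 2.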